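A few compounds are considered here, and "the series" means these few. Any claim that something is new, unique, unknown or untested is made for them only; others in the source may bear on it.

In a functional assay on NCI-H460 cells (Homo sapiens) for cytotoxicity, read by MTT assay, with a stated time of 72 h (on this read-out lower numbers stand for stronger inhibition and higher numbers for weaker inhibition), compound 2 `CN(C)Cc1ccc2nc(NC(=O)N/N=C/c3cn(Cc4ccccc4Cl)c4ccccc34)sc2c1` gives 1600 nM and compound 1 `CCN(CC)Cc1ccc2nc(NC(=O)N/N=C/c3cn(Cc4ccc(C(C)(C)C)cc4)c4ccccc34)sc2c1` gives 1670 nM as its value, so these two numbers lie within the scatter of each other and neither stands apart. Compound 3 `CN(C)Cc1ccc2nc(NC(=O)N/N=C/c3cn(Cc4ccc(C(C)(C)C)cc4)c4ccccc34)sc2c1` has no number yet and differs from compound 2 by one change, 4-(tert-butyl)phenyl in place of 2-chlorophenyl on a saturated chain carbon bound to an aromatic nitrogen on a saturated chain carbon bound to an aromatic nitrogen, which reads as 2-chlorobenzyl to 4-(tert-butyl)benzyl when cut one bond further out. Within the data shown here, no step between measured compounds isolates this change, so the expectation rests on two values only. Compound 1, which carries the entering 4-(tert-butyl)phenyl, stands at 1670 nM in this read-out, and compound 2, which does not carry it, stands at 1600 nM in the same band. The expected step in this assay is a 1.1-fold lower number from compound 2 to compound 3 (0.03 log units; within the scatter) and is not expected to exceed the scatter in either direction. The estimated value for compound 3 is 1500 nM with an expected range from 700 nM to 3500 nM for repeat measurements.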

Compound 3, half-maximal inhibitory concentration: 810 nM
Compound 3: the middle estimate sits 1.9-fold (0.27 log units) above what was measured; the range from low to high includes it.
By their numbers in this assay, from the lowest: compounds 3, 2 and 1 (each within the scatter of the next, the first and the last beyond it).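

In this assay, among these compounds, 4-(tert-butyl)phenyl in place of 2-chlorophenyl on a saturated chain carbon bound to an aromatic nitrogen gives a 2.0-fold lower number from compound 2 to compound 3 (0.30 log units; within the scatter), the first direct reading of this change, and it leaves the two groups not clearly told apart at this place. The amine end also gets its first direct reading: with 4-(tert-butyl)phenyl held fixed, dimethylamino in place of diethylamino on a saturated chain carbon bound to an aromatic carbon gives a 2.1-fold lower number from compound 1 to compound 3 (0.31 log units; beyond the scatter), a modest step, and the only one here that clears the scatter. Nothing on hand bears on the size of either step.

As far as these compounds go, each change is read on a single background, so whether the exchange of diethylamino for dimethylamino gives a similar step with 2-chlorophenyl in place remains open. Also open, from the compounds shown here alone, is how a cyclic amine such as morpholine or piperidine on the same saturated chain carbon, or 4-methoxyphenyl in place of 4-(tert-butyl)phenyl, would read in this assay.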